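Ortho-chloro on the Benzamide of an Orexin Agonist Series

The source may report more compounds than this note shows. Statements on the series, on what has been measured and on what is new or still open speak of the compounds shown alone.

Compound 1: `COc1ccccc1C(=O)NCCNc1cccc(NS(=O)(=O)c2cc(-c3cccc(N)c3)ccc2OC)c1` with > 1000 nM in an assay on CHO-K1 cells for agonist activity at Orexin receptor type 2 (Homo sapiens), read by a luciferase reporter; on this read-out higher numbers stand for an effect only at larger amounts of compound and lower numbers for an effect already at smaller amounts.
Compound 2: `COc1ccc(-c2cccc(C(=O)N(C)C)c2)cc1S(=O)(=O)Nc1cccc(NCCNC(=O)c2ccccc2)c1` with > 10000 nM in this assay.

In this assay compound 1 gives only a limit, > 1000 nM, as the line the limit of > 1000 nM in this assay, at which 1 of the 2 values shown sits, makes plain. Compound 2 likewise gives only a limit in this assay, > 10000 nM, which the limit of > 10000 nM in this assay, at which 1 of the 2 values shown sits, records. For the measured compounds named here, both measured compounds therefore sit at limits rather than at numbers, and no step between them can be sized.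

Compound 3, `COc1ccc(-c2cccc(C(=O)N(C)C)c2)cc1S(=O)(=O)Nc1cccc(NCCNC(=O)c2ccccc2Cl)c1`, is compound 2 with a single change: chloro in place of hydrogen on an aromatic carbon of the benzamido group.

No measured step sizes this change. Since compound 2 reports only a limit, the step from compound 2 to compound 3 is expected to be an at least 1.2-fold lower number from compound 2 to compound 3 (0.09 log units; that floor lies within the scatter), most likely none beyond the scatter. Compound 3 is accordingly estimated at 8000 nM, between 2000 nM and 30000 nM, with a fair chance that this assay again returns only a limit.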

Compound 3, half-maximal effective concentration: 31 nM
Compound 3: middle estimate off by 260-fold (2.41 log units), on the high side; the measured number lies below the stated range.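

In this assay, for the compounds shown here, chloro in place of hydrogen on an aromatic carbon of the benzamido group, ortho to a large group, gives an at least 320-fold lower number from compound 2 to compound 3 (2.50 log units; beyond the scatter) and so yields the first number rather than a limit. Going by these compounds alone, the earlier compounds gave only limits, so this is the first sign that this one place on the benzamido group can decide whether the compound shows an effect at small amounts, and the printed size of the step is only a floor. Nothing measured here gives a reason for the step.

Going by these compounds, it remains open whether chloro is needed or whether fluoro, bromo, methyl or trifluoromethyl on the same carbon would serve as well. Equally open, on these data alone, is whether chloro on another carbon of that ring would give a step of this kind.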